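The compounds below may be only part of what the source reports. "The series", "measured", "known", "first", "only" and "open" are said of these compounds alone.

Compound 3 `CC(C)C(=O)Nc1cccc(C2CCN(Cc3ccc(Oc4ccccc4)cc3)CC2)c1` gives the lowest number of the three measured compounds in an assay on isolated protein for displacement of a labelled ligand from melanin-concentrating hormone receptor 1 (Rattus norvegicus) (a lower number here means a stronger inhibitor, a higher number a weaker inhibitor), at 10 nM. Among the measured compounds shown here, compound 1 `CC(=O)Nc1cccc(C2CCN(CCCC(=O)c3ccc(Cl)cc3)CC2)c1` gives 70 nM, and compound 2 `O=C(CCCN1CCC(c2cccc(NC(=O)C3CCCCC3)c2)CC1)c1ccc(Cl)cc1` gives 200 nM; the only single-change step among them, a 2.9-fold higher number from compound 1 to compound 2 (0.46 log units; beyond the scatter), concerns the group on the carbonyl carbon and not the oxygen on the aromatic ring. Compound 4 `CC(C)C(=O)Nc1cccc(C2CCN(Cc3ccc(Oc4ccc(Cl)c(Cl)c4)cc3)CC2)c1` differs from compound 3 by 3,4-dichlorophenyl in place of phenyl on an oxygen on an aromatic ring. For the measured compounds named here, no measured step touches that part of the molecule, so the three values offer nothing to size this change from. Compound 4 is expected to give about 5 nM, within 1.5 nM to 20 nM. The step of a 2.0-fold lower number from compound 3 to compound 4 (0.30 log units; within the scatter) is accordingly expected to be small, possibly within the scatter.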

Compound 4, inhibition constant: 8.2 nM
Beside the measured number, compound 4's estimate is 1.6-fold (0.21 log units) below it, and the stated range covers the measured number.
By their numbers in this assay, from the lowest: compounds 4 and 3 (each within the scatter of the next); then compound 1; then compound 2.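

In this assay, the step of a 1.2-fold lower number from compound 3 to compound 4 (0.09 log units; within the scatter) shows that 3,4-dichlorophenyl can stand in place of phenyl on this oxygen without a change beyond the scatter. This outer ring therefore carries two added chlorine atoms with no measurable cost in binding, at least in this one pair. No measurement shown here bears on the reason for this result. Still open, on these data alone, is whether a ring carrying one chlorine, an amine or a carboxylic acid would give a similar number. A longer chain between this oxygen and the ring also remains to be judged.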